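The compounds below may be only part of what the source reports. "The series", "measured", "known", "first", "only" and "open" are said of these compounds alone.

Compound 1 `CCO/N=C1\C(=O)N(CCCCCOc2ccc3oc(-c4ccc(OC)cc4)c(C(=O)OCC)c3c2)c2ccc(F)cc21`: 32 ug/mL
Compound 2 `CCOC(=O)c1c(-c2ccc(OC)cc2)oc2ccc(OCCCCCN3C(=O)/C(=N\OC)c4cc(F)ccc43)cc12`: 32 ug/mL

Both values come from an ADME assay on Vero cells (Chlorocebus sabaeus) for cytotoxicity, read by MTT assay, with a stated time of 72 h; on this read-out higher numbers stand for lower toxicity in this test and lower numbers for higher toxicity in this test. On these numbers, compound 1 stands at 32 ug/mL, level with its nearest neighbour compound 2 at 32 ug/mL.

The next compound, compound 3 `CCO/N=C1\C(=O)N(CCCCCOc2ccc3oc(-c4ccc(OC)cc4)c(C(=O)OCC)c3c2)c2ccc(OC)cc21`, has not yet been measured. It differs from compound 1 as follows: methoxy in place of fluoro on an aromatic carbon. In words, this is methoxy in place of fluoro on an aromatic carbon, while the rest of the structure stays the same.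

Within the data shown here, only one measured step is available: no change at the digits printed from compound 1 to compound 2 (within the scatter). It concerns a different group, so it bears on this change only indirectly. It shows that one small edit elsewhere in the structure left this assay unmoved. Among the measured compounds shown here, no measured compound replaces the fluoro, so the data give no direct evidence for this change and no basis for a direction.

The expected step is no change at the digits printed from compound 1 to compound 3 (within the scatter), with no shift beyond the scatter anticipated in this assay. For compound 3 the estimated value is 32 ug/mL, with an expected range of 14 ug/mL to 72 ug/mL.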

Compound 3, half-maximal cytotoxic concentration: 16 ug/mL
Estimate against measurement, compound 3: 2.0-fold (0.30 log units) above; measured number inside the range.
By their numbers in this assay, from the lowest: compounds 3, 1 and 2 (each within the scatter of the next).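

In this assay, among these compounds, the exchange of fluoro for methoxy gives a 2.0-fold lower number from compound 1 to compound 3 (0.30 log units; within the scatter) and so supplies the first direct reading at this aromatic carbon, meta to a fused ring and para to a fused ring, whereas the earlier step from the first pair concerned a different place in the structure. Methoxy brings 2 heavy atoms and 1 hydrogen-bond acceptor where fluoro brought 1 heavy atom and 0 hydrogen-bond acceptors, yet on this read-out the two compounds are not separated beyond the usual scatter of repeated measurements. Nothing at hand gives a measured property of either group or any other explanation for the printed difference.

With only fluoro and methoxy shown at this carbon, the series says nothing yet about how an amine, a carboxylic acid or a longer alkoxy chain would read there, so no trend can be drawn for the position from these two groups alone. As far as these compounds go, it also remains open whether the exchange of fluoro for methoxy reads the same way when combined with the other edit seen in compound 2.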